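This account rests on a few compounds, and the source may have more. Where it says the series, first, only, none or still open, it means among the compounds named here.

Measured compounds:
- compound 1, `CCC/C=C\C(=O)Nc1cc(Nc2nccc(-c3cn(C)c4ccccc34)n2)c(OC)cc1N(C)CCN(C)C`: 1220 nM
- compound 2, `CC/C=C\C(=O)Nc1cc(Nc2ncc(C#N)c(-c3cn(C)c4ccccc34)n2)c(OC)cc1N(C)CCN(C)C`: 1150 nM
- compound 3, `COc1cc(N(C)CCN(C)C)c(NC(=O)/C=C\C(C)C)cc1Nc1ncc(C#N)c(-c2cn(C)c3ccccc23)n1`: 1110 nM

In a functional assay on NCI-H1975 cells (Homo sapiens) for antiproliferative activity, read by MTT assay, with a stated time of 72 h (on this read-out lower numbers stand for stronger inhibition and higher numbers for weaker inhibition), the three compounds give numbers that all lie within the scatter of one another. Compound 3 sits at the low end of the set, but its gaps to compound 2 and to compound 1 are both within the scatter, so no ranking among the three is claimed.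

Among the measured compounds shown here, the only single-point step among the measured compounds is the chain change from compound 2 to compound 3, which gave a 1.0-fold lower number from compound 2 to compound 3 (0.02 log units; within the scatter). Compound 1 and compound 2 differ in two places and show numbers that are again within the scatter of each other.

Compound 4, `CCC/C=C\C(=O)Nc1cc(Nc2ncc(C#N)c(-c3cn(C)c4ccccc34)n2)c(OC)cc1N(C)CCN(C)C`, has not yet been measured in this assay. It differs from compound 3 by propyl in place of isopropyl on a double-bonded chain carbon bound to a double-bonded chain carbon. For the measured compounds named here, the one step that bears on this change, from compound 2 to compound 3, was within the scatter, and every rearrangement of the short chain seen so far has left the number essentially where it was. On that basis the step from compound 3 to compound 4 is expected to be within the scatter, a 1.0-fold higher number from compound 3 to compound 4 (0.02 log units; within the scatter), with no direction favoured. Compound 4 is therefore estimated at 1150 nM, in a range of 600 nM to 2300 nM.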

Compound 4, half-maximal inhibitory concentration: 823 nM
The estimate for compound 4 lay 1.4-fold (0.15 log units) above the measured number; the measured number falls inside the stated range.
By their numbers in this assay, from the lowest: compounds 4, 3, 2 and 1 (each within the scatter of the next).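

In this assay, propyl in place of isopropyl on a double-bonded chain carbon bound to a double-bonded chain carbon gives a 1.3-fold lower number from compound 3 to compound 4 (0.13 log units; within the scatter) and so does not separate the straight chain from the branched one at this place. Among the compounds shown here, compound 4 also supplies two further single-place reads: methyl in place of hydrogen on a saturated chain carbon, two bonds along the chain from a double-bonded chain carbon, gives a 1.4-fold lower number from compound 2 to compound 4 (0.15 log units; within the scatter) and leaves the chain extension unresolved, while cyano in place of hydrogen on an aromatic carbon gives a 1.5-fold lower number from compound 1 to compound 4 (0.17 log units; within the scatter) and isolates the nitrile for the first time, again without a resolved effect. No accompanying measurement offers an explanation for these three steps staying within the scatter.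

Still open, from the compounds shown here alone, is whether a longer chain such as hexyl, a ring such as cyclopropyl, or a chain ending in a dimethylamino group or a hydroxyl would move the number beyond the scatter at this place. Also open, going by these compounds, is whether a chlorine or a trifluoromethyl group in place of the nitrile on the same aromatic carbon would do so.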